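The compounds below may be only part of what the source reports. "The series", "measured", "known", "first", "only" and "open" are said of these compounds alone.

Measured so far:
compound 1 `C=CCc1cc(C(C)=O)c(O)cc1OCCCC#N`: 47%
compound 2 `C=CCc1cc(C(C)=O)c(O)cc1OCCCCCCC#N`: 97%
compound 3 `C=CCc1cc(C(C)=O)c(O)cc1OCCCCCCCCCCC#N`: 50%

In an assay on isolated protein for inhibition of leukotriene B4 receptor 1 (Homo sapiens), tested at 10 uM (a lower number here means less inhibition, a higher number more inhibition at the concentration tested (going by the name of the read-out)), compound 3 stands second highest of the three numbers; its value lies within the scatter of compound 1 and far below compound 2. Compound 4 `C=CCc1cc(C(C)=O)c(O)cc1OCCCCCC` differs from compound 3 in one place: hydrogen in place of 4-cyanobutyl on a saturated chain carbon, six bonds along the chain from an oxygen on an aromatic ring. Neither measured step tests this change directly. The steps of a number 50 percentage points higher from compound 1 to compound 2 (beyond the scatter) and a number 47 percentage points lower from compound 2 to compound 3 (beyond the scatter) both shift the position of the nitrile along the chain and show that this assay responds strongly to such changes, but none removes the nitrile. The expectation is therefore loose: the step of a number 10 percentage points lower from compound 3 to compound 4 (within the scatter) is estimated to be small, with a wide range in either direction. Compound 4 is expected to give 40%, within 10% to 80%.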

Compound 4, a percentage reported as inhibition, at one concentration (the size of the read-out at that concentration, not a potency): 50%
Beside the measured number, compound 4's estimate is 10 percentage points below it; low and high end bracket the measured number.
By their numbers in this assay, from the lowest: compounds 1, 3 and 4 (each within the scatter of the next); then compound 2.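

In this assay the steps of no change at the digits printed from compound 3 to compound 4 (within the scatter) and a number 3 percentage points higher from compound 1 to compound 4 (within the scatter) show that a chain with no nitrile reads level with the nitrile chains of compound 1 and compound 3. Hydrogen in place of cyano, by contrast, gives a number 47 percentage points lower from compound 2 to compound 4 (beyond the scatter) in this series. The nitrile as such therefore does not set the number, and only its placement in compound 2 stands apart among the compounds shown.

Nothing at hand explains this difference. Open, on these data alone, is whether an amine or a carboxylic acid at that chain end would hold the number of compound 2.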